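A few compounds are considered here, and "the series" means these few. Any claim that something is new, unique, unknown or untested is made for them only; others in the source may bear on it.

Compound 1 `Cn1cc(/C=C2/C(=O)Nc3ccccc32)c2cc(Nc3nccc(-c4ccccc4)n3)ccc21` is the only one of these three with a result so far: in an ADME assay on RWPE-1 cells (Homo sapiens) for cytotoxicity, read by MTT assay, with a stated time of 48 h (a lower number here means a stronger inhibitor, a higher number a weaker inhibitor), compound 1 gives 95600 nM. Compound 2 `COc1ccc(-c2ccnc(Nc3ccc4c(c3)c(/C=C3/C(=O)Nc5ccccc53)cn4C)n2)cc1` has no number in this assay: for compound 2 the record reads "not determined" (no result reported), so nothing places it. Compound 3 `Cn1cc(/C=C2/C(=O)Nc3ccccc32)c2cc(Nc3nccc(-c4ccc(F)cc4)n3)ccc21` differs from compound 2 by fluoro in place of methoxy on an aromatic carbon. Among the compounds with values here, no measured step covers this change, so the expectation is that compound 3 stays near compound 1, whose result was 95600 nM, with any shift no larger than the usual scatter. Compound 3 is therefore expected to give roughly 90000 nM in this assay, within a range from 30000 nM to 300000 nM.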

Compound 3, half-maximal inhibitory concentration: 168000 nM
Compound 3: the middle estimate sits 1.9-fold (0.27 log units) below what was measured, within the range that was stated.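

In this assay, fluoro in place of hydrogen on an aromatic carbon, para to a large group, gives a 1.8-fold higher number from compound 1 to compound 3 (0.24 log units; within the scatter) with the rest of the molecule unchanged. At this position, then, the two compounds cannot be told apart in this cell test, so swapping hydrogen for fluoro leaves the reading where it was. Compound 2 has no result, so its step to compound 3 cannot be read, and the compounds shown leave open how an amine or a carboxylic acid would read here. No measurement shown here offers an explanation for this result.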